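Swapping the Ring Nitrogen Substituent: Amide Versus Indolylmethyl

This account rests on a few compounds, and the source may have more. Where it says the series, first, only, none or still open, it means among the compounds named here.

Measured compounds:
Compound 1 `O=C(c1ccc(F)cc1)N1CCC(NCCSC(c2ccc(F)cc2)c2ccc(F)cc2)CC1` gives 7.04 nM in an assay on membranes from striatum (strain Sprague-Dawley) for displacement of a labelled ligand from sodium-dependent dopamine transporter (Rattus norvegicus), read by scintillation counting, with a stated time of 120 min; on this read-out higher numbers stand for weaker inhibition and lower numbers for stronger inhibition.
Compound 2 `Fc1ccc(C(SCCNC2CCN(Cc3cc4ccccc4[nH]3)CC2)c2ccc(F)cc2)cc1` gives 179 nM in this assay.

Compound 2 stands at the highest of the two numbers recorded in this assay; its nearest neighbour is compound 1, and the step of a 25-fold higher number from compound 1 to compound 2 (1.41 log units; beyond the scatter) separates them. Compound 3 `O=C(C1CC1)N1CCC(NCCSC(c2ccc(F)cc2)c2ccc(F)cc2)CC1` has not yet been measured in this assay. It differs from compound 2 in one place: cyclopropylcarbonyl in place of (1H-indol-2-yl)methyl on an amine nitrogen in a ring. Within the data shown here, the only measured step that bears on this change is a 25-fold higher number from compound 1 to compound 2 (1.41 log units; beyond the scatter), in which an amide on that ring nitrogen gave way to the (1H-indol-2-yl)methyl group and the number rose by a large amount. Compound 3 moves in the opposite direction, restoring a carbonyl on the ring nitrogen, though with a cyclopropyl rather than a 4-fluorophenyl attached to it. A step back toward the number of compound 1 is therefore expected, with an estimated 9.0-fold lower number from compound 2 to compound 3 (0.95 log units; beyond the scatter), though the smaller acyl group leaves room for it to fall short of compound 1. For compound 3 the expected value in this assay is 20 nM, with a likely range from 5 nM to 80 nM.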

Compound 3, inhibition constant: 178 nM
The estimate for compound 3 lay 8.9-fold (0.95 log units) below the measured number, outside the stated range (above it).
By their numbers in this assay, from the lowest: compound 1; then compounds 3 and 2 (each within the scatter of the next).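

In this assay, a carbonyl on the ring nitrogen does not on its own go with the low number of compound 1: cyclopropylcarbonyl in place of (1H-indol-2-yl)methyl gives a 1.0-fold lower number from compound 2 to compound 3 (0.00 log units; within the scatter), so these two very different groups cannot be told apart at this position. What separates compound 1 from compound 3 is the group on the carbonyl carbon, with cyclopropyl in place of 4-fluorophenyl giving a 25-fold higher number from compound 1 to compound 3 (1.40 log units; beyond the scatter), a large step, and among these three compounds only the one with the 4-fluorophenyl amide reaches the low end of the scale. Nothing measured here accounts for why the group on the carbonyl carbon matters so much or why the two other groups end up level.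

The compounds shown leave open whether the fluorine matters or whether a plain benzoyl or a cyclohexylcarbonyl on the ring nitrogen would hold the low number. They also leave open whether the carbonyl is needed at all once the 4-fluorophenyl is present, a question that a 4-fluorobenzyl group on the same nitrogen would address.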